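The source may hold more compounds than are shown below. What is called first, only, known or untested is meant among the compounds shown, and "the series" means these compounds.

Measured compounds:
compound 1 `Fc1ccc(-c2cn3nc(Cc4ccc(Cl)cc4)sc3n2)cc1`; in a functional assay on HeLa cells (Homo sapiens) for cytotoxicity, with a stated time of 72 h (a lower number here means a stronger inhibitor, a higher number a weaker inhibitor), compound 1 gives > 250000 nM, a limit of the assay, not a number.
compound 2 `COc1ccc(-c2cn3nc(Cl)sc3n2)cc1`; in this assay compound 2 gives > 250000 nM, again a limit of the assay.
compound 3 `Cc1ccc(-c2cn3nc(Cc4ccc(Cl)cc4)sc3n2)cc1`; in this assay compound 3 gives > 250000 nM, also a limit of the assay.

Compound 3 therefore has no number at all in this assay, only a limit, and it stands where the whole shown series stands: at the limit of > 250000 nM in this assay, at which 3 of the 3 values shown sit. Among the measured compounds shown here, the one step between measured compounds that touches compound 3, a step that the two limits leave unreadable from compound 1 to compound 3, runs between two limits and its size cannot be read.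

Compound 4 `Clc1ccc(Cc2nn3cc(-c4ccccc4)nc3s2)cc1` differs from compound 3 by hydrogen in place of methyl on an aromatic carbon. For the measured compounds named here, the only measured step that bears on this change is the unreadable one from compound 1 to compound 3, so no size and no direction can be taken from the data for the step into compound 4. With all three values sitting at the limit, the expectation is that compound 4 will again return a limit rather than a number in this assay. The step from compound 3 to compound 4 is accordingly estimated as a step that the limit leaves unreadable from compound 3 to compound 4, nothing beyond the scatter. Compound 4 is estimated at 300000 nM, with a range from 100000 nM to 1000000 nM.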

Compound 4, half-maximal inhibitory concentration: > 250000 nM
Compound 4 was reported as a limit (the forecaster's own chance of this, stated with the estimate: 90%); the middle value lies beyond the limit too.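

Among the compounds shown here, neither the step from compound 3 to compound 4 nor the one from compound 1 to compound 4 can be read, as in this assay both ends of each are limits, not numbers. The series stays at a single limit: the limit of > 250000 nM in this assay, at which 4 of the 4 values shown sit.

The compounds shown leave open how hydrogen, methyl and fluoro on that aromatic carbon compare, and which change to the shared core would give a number in this assay.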